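The source may report more compounds than this note shows. Statements on the series, on what has been measured and on what is new or still open speak of the compounds shown alone.

Working notes on the series. The shared core carries a carboxymethyl group and a bis(4-fluorophenyl)methyl group, and the aromatic substituent next to the ring nitrogen is varied. Compound 1 `N#Cc1ccc(-c2nc(C(c3ccc(F)cc3)c3ccc(F)cc3)sc2CC(=O)O)cc1` bears 4-cyanophenyl there and in an in vitro functional assay on HEK285-7 cells for antagonist activity at prostaglandin D2 receptor 2 (Homo sapiens), read by BRET and beta-arrestin recruitment (a higher number here means a weaker inhibitor, a lower number a stronger inhibitor), compound 1 gives 1500 nM. Within the data shown here, compound 2 `NS(=O)(=O)c1cccc(-c2nc(C(c3ccc(F)cc3)c3ccc(F)cc3)sc2CC(=O)O)c1` bears 3-sulfamoylphenyl; in this assay compound 2 gives 710 nM, the lowest of the two numbers so far, the nearest being compound 1. Among the measured compounds shown here, the only measured step at this position is a 2.1-fold lower number from compound 1 to compound 2 (0.32 log units; beyond the scatter).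

Compound 3 `O=C(O)Cc1sc(C(c2ccc(F)cc2)c2ccc(F)cc2)nc1-c1cn[nH]c1` is not yet measured. The change is 1H-pyrazol-4-yl in place of 3-sulfamoylphenyl on an aromatic carbon. For the measured compounds named here, it bears on the same position as the step from compound 1 to compound 2, which was modest; that step is the only guide, and it gives no direction for a different aromatic group. A step of similar size, in either direction, or none beyond the scatter, is therefore expected, written as a 1.4-fold higher number from compound 2 to compound 3 (0.15 log units; within the scatter). For compound 3 in this assay the estimate is 1000 nM, with a range from 300 nM to 3500 nM.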

Compound 3, half-maximal inhibitory concentration: 220 nM
Beside the measured number, compound 3's estimate is 4.5-fold (0.66 log units) above it; measured number below the stated range.
By their numbers in this assay, from the lowest: compound 3; then compound 2; then compound 1.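

At this position, a smaller five-membered aromatic ring with 2 hetero atoms can replace a six-membered aromatic ring of carbon only without loss: in this assay, the change to 1H-pyrazol-4-yl gives a 3.2-fold lower number from compound 2 to compound 3 (0.51 log units; beyond the scatter). Against 4-cyanophenyl, the same ring gives a 6.8-fold lower number from compound 1 to compound 3 (0.83 log units; beyond the scatter), which makes compound 3 the strongest inhibitor of the three, and so neither the nitrile nor the sulfamoyl group is needed at this position for a low number. Nothing measured here accounts for the drop.

The swap from 3-sulfamoylphenyl to 1H-pyrazol-4-yl changes ring size, ring hetero atoms and heavy-atom count together, so the compounds shown do not separate the contribution of each. Open questions are how an unsubstituted phenyl, a 1-methylpyrazol-4-yl with no ring hydrogen-bond donor, or an imidazolyl with its two ring nitrogens placed differently would compare with compound 3 at this position.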